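The compounds below may be only part of what the source reports. "The series", "measured", "known", "first", "only" and "open" are said of these compounds alone.

Working notes on the series, read in a functional assay on K562 cells (Homo sapiens), read by MTT assay, with a stated time of 72 h; on this read-out higher numbers stand for weaker inhibition and lower numbers for stronger inhibition. Compound 1 (`C#Cc1cn([C@@H]2O[C@H](CO)[C@@H](O)[C@H]2O)c2ncnc(OC)c12`) gives 300 nM, the lowest number of the set. Compound 3 (`C#Cc1cn([C@@H]2O[C@H](CO)[C@@H](O)[C@H]2O)c2ncnc(C)c12`) gives 6920 nM, the nearest measured number to it. Compound 2 (`C#Cc1cn([C@@H]2O[C@H](CO)[C@@H](O)[C@H]2O)c2ncnc(NC)c12`) gives > 20000 nM, which is a limit of the assay and not a number.

Compound 4 (`C#Cc1cn([C@@H]2O[C@H](CO)[C@@H](O)[C@H]2O)c2nc(N)nc(OC)c12`) is not yet measured and keeps the methoxy group of compound 1. The change is amino in place of hydrogen on an aromatic carbon, between two ring nitrogen atoms. Among the measured compounds shown here, no measured step touches that carbon, so the evidence is indirect. The nearest guide is the replacement of the methoxy group, which raises the number in both cases: an at least 66-fold higher number from compound 1 to compound 2 (1.82 log units; beyond the scatter) and a 23-fold higher number from compound 1 to compound 3 (1.36 log units; beyond the scatter), both large. The remaining step, an at least 2.8-fold lower number from compound 2 to compound 3 (0.46 log units; beyond the scatter), is at least modest. this assay therefore responds strongly to changes on this ring, and compound 1 already holds the lowest number, so a rise is more likely than a fall. A large upward step is expected, estimated as a 10-fold higher number from compound 1 to compound 4 (1.00 log units; beyond the scatter). For compound 4 the expected value is 3000 nM, with an estimated range of 500 nM to 20000 nM.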

Compound 4, half-maximal inhibitory concentration: > 20000 nM
Compound 4 was reported as a limit; the forecaster's own chance of this, stated with the estimate: 20%; at least 6.6-fold (0.82 log units) between middle value and limit.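

Among the compounds shown here, the carbon between two ring nitrogen atoms, which no earlier step touched, also responds strongly in this assay: with the methoxy group kept, amino in place of hydrogen gives an at least 66-fold higher number from compound 1 to compound 4 (1.82 log units; beyond the scatter). Compound 4 gives > 20000 nM, which is a limit of the assay and not a number. The step therefore fixes only a minimum size for the change, and its full size stays unread, with the same limit also holding for another compound of the series: the limit of > 20000 nM in this assay, at which 2 of the 4 values shown sit.

The compounds shown leave open whether this rise belongs to amino specifically or would follow any group on that carbon, a question that a methyl, fluorine or hydroxyl group there, with the methoxy group kept, would address. Also open, from the compounds shown here alone, is whether a longer chain such as ethoxy in place of methoxy would keep the number that compound 1 gives, 300 nM. Compounds 2 and 4, which differ in two places and both stand at a limit, cannot be ranked against each other.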